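Changing the Aryl Group on the Sulfonyl Sulfur

The source may report more compounds than this note shows. Statements on the series, on what has been measured and on what is new or still open speak of the compounds shown alone.

Compound 1 `CC(=O)Nc1ccc(S(=O)(=O)NNC(=O)c2cccnc2Nc2ccc(Cl)cc2)cc1`: < 100000 nM
Compound 2 `O=C(NNS(=O)(=O)c1ccc(F)cc1)c1cccnc1Nc1ccc(Cl)cc1Cl`: 30900 nM

In a functional assay on NCI-H322 cells (Homo sapiens) for antiproliferative activity (a lower number here means a stronger inhibitor of growth, a higher number a weaker inhibitor of growth), compound 1 gives < 100000 nM, and this is a limit of the assay rather than a measured number (the limit of < 100000 nM in this assay, at which 1 of the 2 values shown sits). Compound 2 in this assay gives 30900 nM. Compound 1 therefore stands nowhere definite on the numbers shown, and the two measured compounds differ in more than one place, so no single step between them can be read off.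

Compound 3 `O=C(NNS(=O)(=O)c1ccc(Cl)cc1Cl)c1cccnc1Nc1ccc(Cl)cc1` has not yet been measured. It differs from compound 1 by 2,4-dichlorophenyl in place of 4-acetamidophenyl on a sulfonyl sulfur. Among the measured compounds shown here, with no measured step of this kind to lean on, the size and direction of the change are open. Compound 3 is expected to give 25000 nM, between 5000 nM and 100000 nM. The step that this estimate means, a step that the limit leaves unreadable from compound 1 to compound 3, is itself only an expectation. For the measured compounds named here, the guess leans on compound 2, which in this assay gives 30900 nM as the only firm number in this set.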

Compound 3, concentration for 50% growth inhibition: 14800 nM
The estimate for compound 3 lay 1.7-fold (0.23 log units) above the measured number; the measured number falls inside the stated range.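

No step from compound 1 to compound 3 can be read, because compound 1 carries only a limit and not a number: the limit of < 100000 nM in this assay, at which 1 of the 3 values shown sits.

Going by these compounds, whether 2,4-dichlorophenyl in place of 4-acetamidophenyl on a sulfonyl sulfur strengthens or weakens growth inhibition in this assay, and by how much, stays open.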